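Fluorinated side chain variant of compound 3

A few compounds are considered here, and "the series" means these few. Any claim that something is new, unique, unknown or untested is made for them only; others in the source may bear on it.

Three compounds of the series have numbers in an ADME assay on microsomes from liver (Homo sapiens) for metabolic stability, with a stated time of 60 min; on this read-out lower numbers stand for a less stable compound and higher numbers for a more stable compound. Compound 1 `Cc1ccc(NC(=O)CC(CCC(=O)O)c2nnc(CCCC(C)C)n2C2CC2)c(C)c1` gives 91%. Compound 2 `Cc1ccc(NC(=O)CC(CCC(N)=O)c2nnc(CCCC(C)C)n2C2CC2)c(C)c1` gives 44%. Among the measured compounds shown here, the one measured single-point step reads a number 47 percentage points lower from compound 1 to compound 2 (beyond the scatter). Compound 3 `Cc1ccc(NC(=O)C[C@H](CCC(=O)O)c2noc(-c3cc(CC(C)C)on3)c2C2CC2)c(Cl)c1` gives 74%, the second highest of the three, standing beyond the scatter below compound 1 and beyond the scatter above compound 2.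

Compound 4 `Cc1ccc(NC(=O)C[C@H](CCC(=O)O)c2noc(-c3cc(C(F)(F)C(C)(C)C)on3)c2C2CC2)c(Cl)c1` is not yet measured in this assay. It differs from compound 3 in one place: 1,1-difluoro-2,2-dimethylpropyl in place of isobutyl on an aromatic carbon. For the measured compounds named here, the only measured step, that between compound 1 and compound 2, concerns a carbonyl carbon and not the group on the five-membered aromatic ring with one nitrogen and one oxygen, so no measured step bears on this change. Without a comparable step, the expectation for compound 4 is a number close to that of compound 3, with a number 6 percentage points higher from compound 3 to compound 4 (within the scatter) expected to stay within the scatter or lean modestly upward. Compound 4 is therefore estimated at 80%, with a range from 62% to 95%.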

Compound 4, percent of the compound remaining: 77%
The estimate for compound 4 lay 3 percentage points above the measured number, within the range that was stated.
By their numbers in this assay, from the lowest: compound 2; then compounds 3 and 4 (each within the scatter of the next); then compound 1.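

In this assay the first step read at this position gives a number 3 percentage points higher from compound 3 to compound 4 (within the scatter) with 1,1-difluoro-2,2-dimethylpropyl in place of isobutyl, so this exchange on the aromatic carbon next to the ring oxygen stays within the scatter. The entering group has 7 heavy atoms against 4 heavy atoms for the one leaving, two of them fluorine, and that larger group still gives a number within the scatter of compound 3. Nothing available explains this result.

The compounds shown leave open whether an amine or a shorter chain such as methyl on this carbon would also stay within the scatter of compound 3. They also leave open whether the same exchange would read alike with an amide in place of the carboxylic acid, the change that gave the large step of a number 47 percentage points lower from compound 1 to compound 2 (beyond the scatter) in the other core.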